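Adding an aryl ring to compound 3

A few compounds are considered here, and "the series" means these few. Any claim that something is new, unique, unknown or untested is made for them only; others in the source may bear on it.

Values in a functional assay on MOLT-4 cells (Homo sapiens) for cytotoxicity, read by CCK-8 assay, with a stated time of 24 h; on this read-out higher numbers stand for weaker inhibition and lower numbers for stronger inhibition:
Compound 1 `C=CC(=O)N1C(=O)CC(c2ccc(C)cc2)Sc2ccccc21`: 87600 nM
Compound 2 `C=CC(=O)N1C(=O)CC(c2ccc(Cl)cc2)Sc2ccccc21`: 82400 nM
Compound 3 `C=CC(=O)N1C(=O)CCSc2ccccc21`: 565000 nM

Of these three, compound 3 has the highest number, 565000 nM, which makes it the weakest inhibitor. The next compound, compound 4 `C=CC(=O)N1C(=O)CC(c2ccccc2Cl)Sc2ccccc21`, is built from it by one change: 2-chlorophenyl in place of hydrogen on a saturated ring carbon. In words, this is 2-chlorophenyl in place of hydrogen on a saturated ring carbon.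

Two measured steps show the same kind of change in reverse, with a substituted phenyl ring replaced by hydrogen: a 6.4-fold higher number from compound 1 to compound 3 (0.81 log units; beyond the scatter), and a 6.9-fold higher number from compound 2 to compound 3 (0.84 log units; beyond the scatter). Both are modest and similar in size. The swap of methyl for chloro, a 1.1-fold lower number from compound 1 to compound 2 (0.03 log units; within the scatter), shows no change beyond the scatter. However, no compound with 2-chlorophenyl has been measured, so the placement of the chlorine remains untested.

Reading those two steps backward, a similar drop is expected in this assay. The expected step is a 6.6-fold lower number from compound 3 to compound 4 (0.82 log units; beyond the scatter). For compound 4 the estimated value is 85000 nM, with an expected range of 35000 nM to 200000 nM.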

Compound 4, half-maximal inhibitory concentration: 80300 nM
Compound 4: the middle estimate sits 1.1-fold (0.02 log units) above what was measured; measured number inside the range.
By their numbers in this assay, from the lowest: compounds 4, 2 and 1 (each within the scatter of the next); then compound 3.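

In this assay, a 2-chlorophenyl group on the saturated ring carbon next to the ring sulfur gives a 7.0-fold lower number from compound 3 to compound 4 (0.85 log units; beyond the scatter), so a third aryl ring at this carbon now lowers the number by a similar amount to the first two. The new ring also shows that the exact substitution on the phenyl ring makes no visible difference among these compounds: a 1.0-fold lower number from compound 2 to compound 4 (0.01 log units; within the scatter) and a 1.1-fold lower number from compound 1 to compound 4 (0.04 log units; within the scatter) are both within the scatter. Nothing measured here explains why an aryl ring at this carbon lowers the number.

Still open, as far as these compounds go, is whether an amine or a carboxylic acid on the phenyl ring, or a longer alkyl chain in place of that ring, would give a similar number. Every compound shown carries the vinylcarbonyl group, so its contribution cannot be read from them.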